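The source may report more compounds than this note shows. Statements on the series, on what has been measured and on what is new or still open speak of the compounds shown alone.

Measured in an assay on CHO cells for displacement of a labelled ligand from adenosine receptor A1 (Homo sapiens), read by scintillation counting, with a stated time of 1 h, tested at 1 uM; a lower number here means less inhibition, a higher number more inhibition at the concentration tested (going by the name of the read-out):
compound 1, `Clc1cccc(-c2cnc(Nc3ccccc3)nc2-c2ccccc2)c1`: 34%
compound 2, `CCCCNc1ncc(-c2cccc(Cl)c2)c(-c2ccccc2)n1`: 56%
compound 3, `OCCCNc1ncc(-c2cccc(Cl)c2)c(-c2ccccc2)n1`: > 80%, which is a limit of the assay

Compound 3 stands highest of the three in this assay, with both steps towards it beyond the scatter. Its own result is only a limit (the limit of > 80% in this assay, at which 1 of the 3 values shown sits), so its exact number is not known. Compound 4, `OCCCCNc1ncc(-c2cccc(Cl)c2)c(-c2ccccc2)n1`, differs from compound 3 in one place: hydroxymethyl in place of hydroxy on a saturated chain carbon, three bonds along the chain from a nitrogen on an aromatic ring. Among the compounds with values here, no measured step lengthens this chain, so the expectation rests on neighbouring steps. The step of a number at least 24 percentage points higher from compound 2 to compound 3 (beyond the scatter) and the step of a number at least 46 percentage points higher from compound 1 to compound 3 (beyond the scatter) both raised inhibition strongly, while a number 22 percentage points higher from compound 1 to compound 2 (beyond the scatter) was smaller. Keeping the hydroxy and adding one chain carbon is expected to leave the number near that of compound 3, with a step of a number at least 2 percentage points lower from compound 3 to compound 4 (that floor lies within the scatter) within the scatter. Compound 4 is expected to give 78% in this assay, between 55% and 92%.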

Compound 4, a percentage reported as inhibition, at one concentration (the size of the read-out at that concentration, not a potency): > 80%
Compound 4 gave a limit, no number; the forecaster's own chance of this, stated with the estimate: 45%; middle value at least 2 percentage points away from the limit.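

In this assay compound 4 gives > 80%, which is a limit of the assay. On the same butyl chain, hydroxy in place of hydrogen gives a number at least 24 percentage points higher from compound 2 to compound 4 (beyond the scatter), and 4-hydroxybutyl in place of phenyl gives a number at least 46 percentage points higher from compound 1 to compound 4 (beyond the scatter). The step between the two hydroxy chains cannot be read, so any effect of the added chain carbon stays hidden: the limit of > 80% in this assay, at which 2 of the 4 values shown sit.

Going by these compounds, how far compound 3 and compound 4 truly differ remains open. So does whether a longer hydroxy chain, or an amine or a carboxylic acid in place of the hydroxy, would hold this level.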